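Amide replacements at the piperidine carbonyl of the shared core

This account rests on a few compounds, and the source may have more. Where it says the series, first, only, none or still open, it means among the compounds named here.

Measured compounds:
compound 1 `Cc1nc(S(C)(=O)=O)ccc1Oc1ncnc(OC2CCN(C(=O)O[C@@H](C)C(F)(F)F)CC2)c1F` with 9.86 nM
compound 2 `Cc1nc(S(C)(=O)=O)ccc1Oc1ncnc(OC2CCN(C(=O)OC3(C(F)(F)F)CCC3)CC2)c1F` with 14.3 nM
compound 3 `Cc1nc(S(C)(=O)=O)ccc1Oc1ncnc(OC2CCN(C(=O)c3nc(C(C)(C)F)no3)CC2)c1F` with 43.4 nM

In a functional assay on isolated protein for inhibition of Glucose-dependent insulinotropic receptor (Homo sapiens), read by HTRF and cAMP accumulation (on this read-out lower numbers stand for an effect already at smaller amounts and higher numbers for an effect only at larger amounts of compound), compound 2 stands second highest of the three numbers; compound 1 lies within the scatter of it, while compound 3 is beyond the scatter (a 3.0-fold higher number from compound 2 to compound 3 (0.48 log units; beyond the scatter)). The step from compound 1 to compound 3 runs the same way (a 4.4-fold higher number from compound 1 to compound 3 (0.64 log units; beyond the scatter)), and between compound 1 and compound 2 there is only a 1.5-fold higher number from compound 1 to compound 2 (0.16 log units; within the scatter).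

Compound 4 `CCc1cnc(C(=O)N2CCC(Oc3ncnc(Oc4ccc(S(C)(=O)=O)nc4C)c3F)CC2)nc1` carries the change (a group of 8 heavy atoms (6 carbon, 2 nitrogen; one six-membered aromatic ring with 2 hetero atoms) in place of a group of 9 heavy atoms (5 carbon, 1 oxygen, 3 fluorine; one four-membered non-aromatic ring of carbon only), on a carbonyl carbon). Within the data shown here, the one measured step that bears on it is the exchange of the carbamate-type group on the carbonyl carbon for an aromatic heterocycle in compound 3, where a 3.0-fold higher number from compound 2 to compound 3 (0.48 log units; beyond the scatter) and a 4.4-fold higher number from compound 1 to compound 3 (0.64 log units; beyond the scatter) were both modest rises. A similar, modest rise in this assay is therefore expected for compound 4, that is a 2.4-fold higher number from compound 2 to compound 4 (0.39 log units; beyond the scatter). The estimated value of compound 4 is 35 nM, with a range from 14 nM to 90 nM.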

Compound 4, half-maximal effective concentration: 4.7 nM
The estimate for compound 4 lay 7.4-fold (0.87 log units) above the measured number, outside the stated range (below it).
By their numbers in this assay, from the lowest: compound 4; then compounds 1 and 2 (each within the scatter of the next); then compound 3.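

At this carbonyl carbon, an aromatic ring with ring nitrogens does not in itself raise the number in this assay: 5-ethylpyrimidin-2-yl gives a 3.0-fold lower number from compound 2 to compound 4 (0.48 log units; beyond the scatter) and a 2.1-fold lower number from compound 1 to compound 4 (0.32 log units; beyond the scatter), the opposite direction to the five-membered aromatic ring of compound 3. The choice of aromatic group matters at this place, with a 9.2-fold lower number from compound 3 to compound 4 (0.97 log units; beyond the scatter), the largest step in the set, and compound 4 now holds the lowest number of the four. Nothing available here accounts for this difference between the two aromatic groups.

With a single six-membered aromatic group shown, the ring and its ethyl substituent cannot be separated as sources of the lower number. From the compounds shown here alone, how far the trend holds with a methyl group, a propyl chain or a nitrile in place of that ethyl remains open.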